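One Phenyl Group Swapped on the Shared Core

This account rests on a few compounds, and the source may have more. Where it says the series, first, only, none or still open, it means among the compounds named here.

- Compound 1 `N#Cc1ccc(F)cc1Cn1c(N2CCC[C@@H](N)C2)nc2c(-c3ccc(F)cc3)c[nH]c2c1=O` has a half-life of 3.01 h here
- Compound 2 `N#Cc1ccc(F)cc1Cn1c(N2CCC[C@@H](N)C2)nc2cc[nH]c2c1=O` has a half-life of 3.33 h here
- Compound 3 `CS(=O)(=O)c1ccc(-c2c[nH]c3c(=O)n(Cc4cc(F)ccc4C#N)c(N4CCC[C@@H](N)C4)nc23)c(F)c1` has a half-life of > 3.33 h here, which is a limit

In an ADME assay on microsomes from liver (Homo sapiens) for metabolic stability, read by LC-MS, tested at 1 mM (a higher number here means that the compound lasts longer, a lower number that the compound disappears faster), compound 3 gives > 3.33 h as a limit and not as a number. Its standing is thus (the limit of > 3.33 h in this assay, at which 1 of the 3 values shown sits) and no more. Compound 4 `CS(=O)(=O)c1ccccc1-c1c[nH]c2c(=O)n(Cc3cc(F)ccc3C#N)c(N3CCC[C@@H](N)C3)nc12` differs from compound 3 in one place (2-(methylsulfonyl)phenyl in place of 2-fluoro-4-(methylsulfonyl)phenyl on an aromatic carbon) where 2-(methylsulfonyl)phenyl stands in place of 2-fluoro-4-(methylsulfonyl)phenyl, on an aromatic carbon of a five-membered aromatic ring.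

Going by the values given here, no measured step makes exactly this change, but three steps touch the same place. The first is a 1.1-fold higher number from compound 1 to compound 2 (0.04 log units; within the scatter) and stays within the scatter. The second is an at least 1.1-fold higher number from compound 1 to compound 3 (0.04 log units; that floor lies within the scatter) and its floor also lies within the scatter. The third is a number no lower from compound 2 to compound 3 (the limit leaves the size open) and its size stays open. this assay therefore gives no reason to expect a change beyond the scatter.

The expected step is a number no higher from compound 3 to compound 4 (the limit leaves the size open) and it is estimated to stay within the scatter. For compound 4 the estimate is 3.3 h with an expected range from 2.2 h to 5 h and a real chance of another limit.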

Compound 4, half-life: > 3.33 h
Compound 4: only a limit was reported; the forecaster's own chance of this, stated with the estimate: 45%; at least 1.0-fold (0.00 log units) between middle value and limit.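

In this assay compound 4 gives > 3.33 h, which is a limit and not a number. With 2-(methylsulfonyl)phenyl at this place, a second phenyl group carrying methylsulfonyl now ends at a limit of the assay: the limit of > 3.33 h in this assay, at which 2 of the 4 values shown sit.

The readable steps are an at least 1.1-fold higher number from compound 1 to compound 4 (0.04 log units; that floor lies within the scatter) and a number no lower from compound 2 to compound 4 (the limit leaves the size open) while the step to compound 4 from compound 3 cannot be read, so the swap of 2-fluoro-4-(methylsulfonyl)phenyl for 2-(methylsulfonyl)phenyl has no readable size here.

Going by these compounds, whether compound 3 or compound 4 differs from compound 1 beyond the scatter stays open. Also open, on these data alone, is what a phenyl group carrying an amine or a carboxylic acid would give on this aromatic carbon of the five-membered ring.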